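The compounds below may be only part of what the source reports. "The series", "measured", "known", "first", "only" and "open" are said of these compounds alone.

Measured compounds:
Compound 1 `C/C=C/C(=O)Nc1cccc(Cn2nc(-c3ccc(Oc4ccccc4)cc3)cc2C(=O)O)c1` gives 24100 nM in a functional assay on Z-138 cells (Homo sapiens) for inhibition, read by luminescence and CellTiter-Glo, with a stated time of 72 h; a higher number here means a weaker inhibitor, a lower number a stronger inhibitor.
Compound 2 `C/C=C/C(=O)Nc1cccc(Cn2nc(-c3ccc(Oc4ccccc4)cc3)cc2CO)c1` gives 5700 nM in this assay.

Among the measured compounds shown here, compound 2 has the lowest of the two numbers measured so far in this assay; its nearest neighbour is compound 1, and the step of a 4.2-fold lower number from compound 1 to compound 2 (0.63 log units; beyond the scatter) shows that the move from carboxy to hydroxymethyl brought a modest gain.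

Compound 3 `C/C=C/C(=O)Nc1cccc(Cn2nc(-c3ccc(Oc4ccccc4)cc3)cc2C(=O)OCC)c1` is not yet measured. It differs from compound 2 by ethoxycarbonyl in place of hydroxymethyl on an aromatic carbon. Compound 3 is therefore the ethyl ester of the acid compound 1. For the measured compounds named here, only one measured step touches this position, a 4.2-fold lower number from compound 1 to compound 2 (0.63 log units; beyond the scatter), and it compares carboxy with hydroxymethyl, not ethoxycarbonyl with either. What can be said is that the acid gives the higher number and the hydroxymethyl the lower one; an ethoxycarbonyl group is neither, so the direction of the step in this assay is open. The expectation for compound 3 is a number near that of compound 2, with wide uncertainty, and the estimated step is a 1.2-fold higher number from compound 2 to compound 3 (0.09 log units; within the scatter). Compound 3 is estimated at 7000 nM in this assay, within a range from 1800 nM to 28000 nM.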

Compound 3, half-maximal inhibitory concentration: 8900 nM
Estimate against measurement, compound 3: 1.3-fold (0.10 log units) below; the range from low to high includes it.
By their numbers in this assay, from the lowest: compounds 2 and 3 (each within the scatter of the next); then compound 1.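

In this assay, esterifying the acid moves the number beyond the scatter (a 2.7-fold lower number from compound 1 to compound 3 (0.43 log units; beyond the scatter)), so the carboxy group of compound 1 now stands apart from two different neutral replacements at this aromatic carbon, not just from hydroxymethyl. Ethoxycarbonyl and hydroxymethyl, by contrast, cannot be told apart here (a 1.6-fold higher number from compound 2 to compound 3 (0.19 log units; within the scatter)): the position takes a group of 5 heavy atoms with 0 hydrogen-bond donors as readily as one of 2 heavy atoms with 1 hydrogen-bond donor, and among these three compounds neither size nor donor count separates the two non-acid groups. No supporting measurement accompanies these numbers, so nothing shown explains why the acid differs from the other two groups. The compounds shown leave open whether a primary carboxamide, an aminomethyl group or a plain hydrogen at this carbon would fall with compound 2 and compound 3 or with compound 1. They also leave open whether a longer ester, such as a butyl ester, would still sit within the scatter of compound 3.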